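Removing the iodine from a hydroxy-bearing pyridine ring

The compounds below may be only part of what the source reports. "The series", "measured", "known", "first", "only" and "open" are said of these compounds alone.

Of the compounds shown here, three have been measured in an assay on HEK293 cells for displacement of a labelled ligand from Neuronal acetylcholine receptor; alpha4/beta2 (Homo sapiens); a lower number here means a stronger inhibitor, a higher number a weaker inhibitor. Compound 1 `c1cncc(N2CCCNCCC2)c1` gives 0.891 nM, and compound 3 `COc1cncc(N2CCCNCCC2)c1` gives 1 nM; these two differ only by a methoxy in place of hydrogen on an aromatic carbon, and the step of a 1.1-fold higher number from compound 1 to compound 3 (0.05 log units; within the scatter) lies within the scatter. For the measured compounds named here, compound 2 `Oc1cc(N2CCCNCC2)cnc1I` gives 21.9 nM, the highest of the three numbers, and it differs from both others in more than one place, so no single step can be drawn from it.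

Compound 4 `Oc1cncc(N2CCCNCC2)c1` is not yet measured. The change from compound 2 to compound 4 is hydrogen in place of iodo on an aromatic carbon. Going by the values given here, no measured step matches this change: the only measured step swaps methoxy for hydrogen, not iodo, and compounds 1 and 3 differ from compound 2 in the ring as well. The expectation for compound 4 therefore rests on little; a modest move toward a lower number in this assay is estimated, as a 2.2-fold lower number from compound 2 to compound 4 (0.34 log units; beyond the scatter). Compound 4 is estimated at 10 nM, with a range from 2 nM to 60 nM.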

Compound 4, half-maximal inhibitory concentration: 2.4 nM
For compound 4 the middle estimate is 4.2-fold (0.62 log units) above the measured one; the measured number falls inside the stated range.
By their numbers in this assay, from the lowest: compounds 1 and 3 (each within the scatter of the next); then compound 4; then compound 2.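

Replacing the iodo group with hydrogen on the aromatic carbon next to the ring nitrogen and ortho to a hydroxy group gives a 9.1-fold lower number from compound 2 to compound 4 (0.96 log units; beyond the scatter) in this assay. At this place, then, the compound with hydrogen binds more strongly than the one with iodo, and a single heavy atom is enough to shift the number clearly. The other step shown, a 1.1-fold higher number from compound 1 to compound 3 (0.05 log units; within the scatter), is a methoxy change on a different core and stays within the scatter, whereas this one does not, and nothing measured here explains the size of this step.

From the compounds shown here alone, it remains open how a chloro or a methyl group at this place would compare with iodo and hydrogen, and whether adding iodo to the core of compound 1 would give a similar step. What the hydroxy group itself contributes is also open, since no pair shown isolates it.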